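Swapping the anilino aryl group on a shared pyrimidine-free core

The compounds below may be only part of what the source reports. "The series", "measured", "known", "first", "only" and "open" are said of these compounds alone.

Among the measured compounds shown here, the series rests on one shared core, and the two measured members differ only in the aryl group carried by the anilino nitrogen. Compound 1 `Cc1cc(Nc2cc(N3CCN(C)CC3)nc(Nc3cccc(Cl)c3)n2)n[nH]1` gives 56.4 nM in a functional assay on MDA-MB-231 cells (Homo sapiens) for antiproliferative activity, read by CCK-8 assay, with a stated time of 72 h; on this read-out higher numbers stand for weaker inhibition and lower numbers for stronger inhibition. Compound 2 `Cc1cc(Nc2cc(N3CCN(C)CC3)nc(Nc3cccc([N+](=O)[O-])c3)n2)n[nH]1`, which carries a nitro in place of the chloro on an aromatic carbon, gives 114 nM in this assay; this step, a 2.0-fold higher number from compound 1 to compound 2 (0.31 log units; beyond the scatter), is the only one the data hold. Within the two numbers shown, compound 2 stands at the higher one.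

Compound 3 `Cc1cc(Nc2cc(N3CCN(C)CC3)nc(Nc3ccc(C#N)cc3)n2)n[nH]1` is not yet measured. It differs from compound 2 by 4-cyanophenyl in place of 3-nitrophenyl on a nitrogen on an aromatic ring. For the measured compounds named here, no measured step follows exactly this exchange, so the only guide is the step from compound 1 to compound 2, which shows that replacing the aryl substituent moves the number by a modest amount. The same kind of change is expected here, with no firm direction. Compound 3 is therefore estimated at 90 nM in this assay, with a range from 30 nM to 300 nM, which corresponds to an expected step of a 1.3-fold lower number from compound 2 to compound 3 (0.10 log units; within the scatter).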

Compound 3, half-maximal inhibitory concentration: 75.7 nM
The estimate for compound 3 lay 1.2-fold (0.08 log units) above the measured number; the measured number falls inside the stated range.
By their numbers in this assay, from the lowest: compounds 1, 3 and 2 (each within the scatter of the next, the first and the last beyond it).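

In this assay the position on a nitrogen on an aromatic ring also accepts 4-cyanophenyl, a group that differs from the earlier two in both its substituent and the number in its name (a 1.5-fold lower number from compound 2 to compound 3 (0.18 log units; within the scatter)) (a 1.3-fold higher number from compound 1 to compound 3 (0.13 log units; within the scatter)). The step from the chloro to the nitro compound was the only one available earlier and lay beyond the scatter, whereas compound 3 lies within the scatter of both compound 1 and compound 2, so the three aryl groups do not fall into two clearly separate levels, even though the two earlier compounds remain apart. No measurement offered here explains these numbers or accounts for why the groups compare as they do.

With the substituent and the number in the group's name changing together, the compounds shown cannot say how much of either exchange belongs to the nitrile itself and how much to where it sits, a question that 3-cyanophenyl or 4-chlorophenyl on the same nitrogen would address. They also leave open how this position would respond to plain phenyl, or to an aryl group carrying an amine or a carboxylic acid.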